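The source may report more compounds than this note shows. Statements on the series, on what has been measured and on what is new or still open speak of the compounds shown alone.

Compound 1 `C=CC1=C(C(=O)O)C(c2ccc(F)cc2)OC1` and compound 2 `C=CC1=C(C(=O)NCc2ccc(OC)c(OC)c2)C(c2ccc(F)cc2)OC1` share the same core and the same vinyl substituent; they differ in the group carried by the carbonyl. In a functional assay on A549 cells (Homo sapiens) for cytotoxicity, read by MTT assay, with a stated time of 24 h (a lower number here means a stronger inhibitor, a higher number a weaker inhibitor), compound 1 reaches only the limit of the assay and gives > 100000 nM. Compound 2 likewise reaches only the limit, giving > 100000 nM in this assay. Compound 2 therefore stands at the limit of > 100000 nM in this assay, at which 2 of the 2 values shown sit, with no number of its own, so nothing about its standing relative to compound 1 can be read from the figures. The next compound, compound 3 `C=CC1=C(C(=O)NCc2ccc(OC)c(OC)c2)C(c2ccc(OC)cc2)OC1`, differs from compound 2 in a single place: methoxy in place of fluoro on an aromatic carbon. Within the data shown here, no measured pair shows what such a change does here, so the size of the step in this assay cannot be drawn from the data; with compound 2 sitting at a limit, nothing points to a move beyond the scatter in either direction. The step from compound 2 to compound 3 is expected to be a step that the limit leaves unreadable from compound 2 to compound 3. Compound 3 is expected once more to reach only the limit, and compound 3 is estimated at 150000 nM, in the range 50000 nM to 500000 nM.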

Compound 3, half-maximal inhibitory concentration: > 100000 nM
Compound 3 was reported as a limit; the forecaster's own chance of this, stated with the estimate: 85%; the middle value lies beyond the limit too.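

In this assay compound 3 gives > 100000 nM as a limit of the assay, not a number. Compound 2 also stands at a limit, so no step can be read between compound 2 and compound 3: the limit of > 100000 nM in this assay, at which 3 of the 3 values shown sit. The compounds shown leave open whether any compound of this kind reaches a number of its own in this assay at all.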